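The compounds below may be only part of what the source reports. "The series", "measured", "known", "first", "only" and "open" are said of these compounds alone.

Working notes on the series. In a functional assay on MCF7 cells (Homo sapiens) for inhibition (on this read-out lower numbers stand for stronger inhibition and higher numbers for weaker inhibition), compound 2 `CC/C(=C(/c1ccc(/C=C/C(=O)O)cc1)c1cc2ccccc2[nH]1)c1cccc(C(F)(F)F)c1` gives 325 nM, the higher of the two numbers in hand; the nearest comparator, compound 1 `CC/C(=C(/c1ccc(/C=C/C(=O)O)cc1)c1cc2ccccc2[nH]1)c1ccccc1`, gives 108 nM in this assay. Within the data shown here, the single measured step between them is a 3.0-fold higher number from compound 1 to compound 2 (0.48 log units; beyond the scatter), which is the only change so far tested at this place on the shared core.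

Compound 3 `CC/C(=C(/c1ccc(/C=C/C(=O)O)cc1)c1cc2ccccc2[nH]1)c1cccc(OC(F)(F)F)c1` is the next member, not yet measured. It differs from compound 2 by trifluoromethoxy in place of trifluoromethyl on an aromatic carbon. Among the measured compounds shown here, no measured step covers this exchange: the one step in hand, a 3.0-fold higher number from compound 1 to compound 2 (0.48 log units; beyond the scatter), concerns trifluoromethyl entering in place of hydrogen, not trifluoromethoxy entering in place of trifluoromethyl. That step was modest, so the substituent at this place moved this assay only moderately once; a second group of this kind at the same place is expected to move it by no more than that, in either direction, and quite possibly not beyond the scatter.

Compound 3 is therefore expected to give about 300 nM in this assay, within 110 nM to 800 nM, a step of a 1.1-fold lower number from compound 2 to compound 3 (0.03 log units; within the scatter) that is expected to lie within the scatter.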

Compound 3, half-maximal inhibitory concentration: 282 nM
Compound 3: middle estimate off by 1.1-fold (0.03 log units), on the high side; low and high end bracket the measured number.
By their numbers in this assay, from the lowest: compound 1; then compounds 3 and 2 (each within the scatter of the next).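

In this assay, the exchange of trifluoromethyl for trifluoromethoxy at this place, read as 3-(trifluoromethyl)phenyl to 3-(trifluoromethoxy)phenyl, gives a 1.2-fold lower number from compound 2 to compound 3 (0.06 log units; within the scatter) and so does not separate the two groups, even though trifluoromethoxy brings one more heavy atom and a counted hydrogen-bond acceptor. Trifluoromethoxy in place of hydrogen gives a 2.6-fold higher number from compound 1 to compound 3 (0.42 log units; beyond the scatter) and thereby adds a second substituent at this place on the same side of compound 1 as the trifluoromethyl of compound 2, with neither of the two substituted compounds going against this pattern. No measurement in hand accounts for either step.

The compounds shown leave open whether a methyl, a methoxy or an amine at this place would also stand apart from compound 1 in this assay or would remain within the scatter of it. They also leave open whether trifluoromethyl and trifluoromethoxy would remain indistinguishable on another aromatic carbon of the same ring.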